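The compounds below may be only part of what the source reports. "The series", "measured", "known", "first", "only" and "open" are said of these compounds alone.

Measured so far in a functional assay on K562 cells (Homo sapiens) for antiproliferative activity, read by MTT assay, with a stated time of 24 h; on this read-out higher numbers stand for weaker inhibition and lower numbers for stronger inhibition:
compound 1 `COc1ccc(C(=O)/C=C/c2ccc(N3CCCC3)cc2)c2c1C=CC(C)(C)O2`: 6180 nM
compound 2 `COc1ccc(/C=C/C(=O)c2ccc(OC)c3c2OC(C)(C)C=C3)cn1`: > 10000 nM

Compound 1 gives a resolved number in this assay, 6180 nM, at the weak end of inhibition. Compound 2 gives only a limit of the assay and not a number, > 10000 nM. Compound 2 therefore stands at the limit of > 10000 nM in this assay, at which 1 of the 2 values shown sits, and no ordering of compound 2 against compound 1 can be read from the two values beyond this.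

Compound 3 `COc1ccccc1/C=C/C(=O)c1ccc(OC)c2c1OC(C)(C)C=C2` differs from compound 2 by 2-methoxyphenyl in place of 6-methoxypyridin-3-yl on a double-bonded chain carbon bound to a double-bonded chain carbon. Going by the values given here, no step between two measured compounds is available in this assay, so the size of such a change has not been seen here. Among the compounds with values here, the only anchor is compound 1, which also carries a carbon-only aromatic ring on the double-bonded chain and gives 6180 nM. On that basis compound 3 is expected to remain weak, with the step from compound 2 an at least 1.2-fold lower number from compound 2 to compound 3 (0.09 log units; that floor lies within the scatter) expected to be small, possibly within the scatter. Compound 3 is estimated at 8000 nM, with a range of 3000 nM to 20000 nM.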

Compound 3, half-maximal inhibitory concentration: > 10000 nM
Compound 3 was reported as a limit (the forecaster's own chance of this, stated with the estimate: 40%); at least 1.2-fold (0.09 log units) between middle value and limit.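

Going by these compounds alone, compound 2 and compound 3 are both reported only as a limit of the assay, not as a number, so no step between them can be read in this assay: the limit of > 10000 nM in this assay, at which 2 of the 3 values shown sit.

From the compounds shown here alone, whether 2-methoxyphenyl in place of 6-methoxypyridin-3-yl changes inhibition at all, and in which direction, remains open in this assay.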